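Swapping Fluoro for Methoxy on an Open-Chain Amide

This account rests on a few compounds, and the source may have more. Where it says the series, first, only, none or still open, it means among the compounds named here.

This study asks how much of each compound is needed in a functional assay on the whole organism with Mus musculus as the target, in the maximal electroshock model; a lower number here means that less compound is needed, a higher number that more compound is needed for the effect. Compound 1, with the structure `COc1ccc(C23CCC(=O)N2CCCO3)cc1`, gives 93.8 mg/kg in this assay. Compound 3, with the structure `O=C1CCCC2(c3ccccc3)OCCCN12`, is reported in this assay only as a limit of < 150 mg/kg, which marks a boundary rather than a measured number. Compound 2, with the structure `O=C(CCC(=O)c1ccc(F)cc1)NCCCO`, is likewise reported in this assay only as a limit of > 400 mg/kg, not a number. Among the three values shown, compound 2 thus sits at a boundary, and one further value is a boundary as well, as described in the limit of > 400 mg/kg in this assay, at which 1 of the 3 values shown sits, and (the limit of < 150 mg/kg in this assay, at which 1 of the 3 values shown sits). Going by the values given here, no pair of measured compounds differs in a single place, so no step is available to guide the next change. Compound 4, with the structure `COc1ccc(C(=O)CCC(=O)NCCCO)cc1`, has not yet been measured in this assay. It differs from compound 2 by methoxy in place of fluoro on an aromatic carbon. Among the compounds with values here, with no measured step of this kind to rest on, the expectation is for no change beyond the usual scatter, with the step from compound 2 to compound 4 estimated at an at least 1.1-fold lower number from compound 2 to compound 4 (0.05 log units; that floor lies within the scatter). Compound 4 is therefore expected to give about 350 mg/kg, within a range from 120 mg/kg to 1000 mg/kg.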

Compound 4, dose for half-maximal effect: > 600 mg/kg
Compound 4: no number, only a limit; the forecaster's own chance of this, stated with the estimate: 60%; middle value at least 1.7-fold (0.23 log units) from the limit.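

Compound 2 and compound 4 are both reported in this assay only as limits, not as numbers, so the step between them cannot be read. The compounds shown leave open how much compound is needed for the effect with either group, and whether methoxy in place of fluoro on an aromatic carbon changes that amount at all.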